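This account rests on a few compounds, and the source may have more. Where it says the series, first, only, none or still open, it means among the compounds named here.

Measured compounds in a functional assay on A549 cells (Homo sapiens) for antiproliferative activity, read by MTT assay, with a stated time of 72 h; a higher number here means a weaker inhibitor of growth, a lower number a stronger inhibitor of growth:
compound 1, `Cc1ccc2nc(-c3ccc(N)cc3)cn2c1`: compound 1 gives > 100000 nM, which is a limit of the assay and not a number.
compound 2, `Cc1ccc2nc(-c3ccc(NCc4ccccc4)cc3)cn2c1`: compound 2 gives 56100 nM.
compound 3, `Cc1ccn2cc(-c3ccc(N)cc3)nc2c1`: compound 3 gives > 100000 nM, again a limit of the assay and not a number.

Compound 1 and compound 3 are built from the same atoms joined differently; the difference between the two cores is not broken down here. On the core of compound 1 the change benzyl in place of hydrogen on a nitrogen on an aromatic ring yields an at least 1.7-fold lower number from compound 1 to compound 2 (0.25 log units; that floor lies within the scatter). Because compound 1 sits at the limit of > 100000 nM in this assay, at which 2 of the 3 values shown sit, the size of this step is only a floor, and that floor lies within the usual scatter.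

Compound 4, `Cc1ccn2cc(-c3ccc(NCc4ccccc4)cc3)nc2c1`, is not yet measured in this assay. It carries the same change, (benzyl in place of hydrogen on a nitrogen on an aromatic ring), on the core of compound 3; the surroundings of the place read the same in both cases, so this is the same change rather than merely the same kind. Compound 3 also sits at the limit of > 100000 nM in this assay, at which 2 of the 3 values shown sit, so the step to compound 4 can likewise only be given against that floor.

Within the data shown here, for compound 4 the expected step is an at least 1.5-fold lower number from compound 3 to compound 4 (0.18 log units; that floor lies within the scatter), resting on an at least 1.7-fold lower number from compound 1 to compound 2 (0.25 log units; that floor lies within the scatter) and on the one number in the set, that of compound 2 at 56100 nM. For compound 4 in this assay the estimate is 65000 nM, between 25000 nM and 200000 nM. Compound 3 is reported only as a limit, and compound 4 may also come back as a limit rather than a number.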

Compound 4, concentration for 50% growth inhibition: 5100 nM
Beside the measured number, compound 4's estimate is 13-fold (1.11 log units) above it; measured number outside the range, below it.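

Working notes on the series: in this assay, benzyl in place of hydrogen on a nitrogen on an aromatic ring gives a large step on the core of compound 3 (an at least 19-fold lower number from compound 3 to compound 4 (1.29 log units; beyond the scatter)), so the change carries over to this core with a gain beyond the scatter. On the core of compound 1 the same change gives only a floor within the scatter (an at least 1.7-fold lower number from compound 1 to compound 2 (0.25 log units; that floor lies within the scatter)), and the data do not show that the step has one size across the two cores: the same change on two cores in this assay, an at least 1.7-fold lower number (0.25 log units; that floor lies within the scatter) from compound 1 to compound 2 and an at least 19-fold lower number (1.29 log units; beyond the scatter) from compound 3 to compound 4; the limit leaves it open whether they differ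

Neither step has a measured starting value, so both sizes remain floors and a transfer of size from one core to the other stays unproven: the limit of > 100000 nM in this assay, at which 2 of the 4 values shown sit.

The compounds shown leave open whether this gain is specific to benzyl or would also appear with methyl, with a longer chain such as phenethyl, or with an acetyl group on the same nitrogen. On these data alone, it also remains open how a chloro or methoxy group on the aromatic ring of the benzyl would read on either core, and whether the two cores would then respond alike.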